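Working notes: methyl in place of tert-butyl

A few compounds are considered here, and "the series" means these few. Any claim that something is new, unique, unknown or untested is made for them only; others in the source may bear on it.

- compound 1 `C=C1CN/C(=N/c2ccccc2)S1`: > 100000 nM, a limit of the assay
- compound 2 `COc1ccc(/C=C2/CN(C)/C(=N/c3ccc(C(C)(C)C)cc3)S2)cc1`: 23500 nM

For the measured compounds named here, in an ADME assay on TERT-RPE1 cells (Homo sapiens) for cytotoxicity, read by MTT assay, with a stated time of 72 h (a higher number here means a weaker inhibitor, a lower number a stronger inhibitor), compound 2 gives 23500 nM, the only actual number so far. Compound 3 `COc1ccc(/C=C2/CN(C)/C(=N/c3ccc(C)cc3)S2)cc1` differs from compound 2 at one place, with methyl in place of tert-butyl on an aromatic carbon. Going by the values given here, no measured step covers this change, so only a small shift toward weaker inhibition in this assay is expected, close to the scatter. The expected change is a 1.6-fold higher number from compound 2 to compound 3 (0.21 log units; within the scatter). For compound 3 the estimated value is 38000 nM, with an expected range of 14000 nM to 90000 nM.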

Compound 3, half-maximal inhibitory concentration: 65700 nM
Estimate against measurement, compound 3: 1.7-fold (0.24 log units) below, within the range that was stated.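

Methyl in place of tert-butyl on an aromatic carbon gives a 2.8-fold higher number from compound 2 to compound 3 (0.45 log units; beyond the scatter) in this assay, the first sign that this position registers in the read-out. This is one modest step from a single pair, so it sets no trend across groups at this carbon. Compound 1 gives only a limit, not a number, and so offers no second comparison: the limit of > 100000 nM in this assay, at which 1 of the 3 values shown sits.

On these data alone, whether an amine or a carboxylic acid on this aromatic carbon would move the value remains open. So does whether the same change behaves alike with another group in place of the methoxy on the other aromatic ring.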